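The source may report more compounds than this note shows. Statements on the series, on what has been measured and on what is new or still open speak of the compounds shown alone.

The measured compounds are compound 1 `COc1cccc(Oc2ccc(CN3C(=O)C(=O)c4cc(OC(F)(F)F)ccc43)cc2)n1` and compound 2 `O=C1C(=O)N(Cc2cccc(-c3ccccc3)c2)c2ccc(OC(F)(F)F)cc21`.

In a functional assay on CHO cells for positive allosteric modulation of muscarinic acetylcholine receptor M5 (Homo sapiens), read by FLIPR and calcium flux, with a stated time of 1 h (on this read-out higher numbers stand for an effect only at larger amounts of compound and lower numbers for an effect already at smaller amounts), compound 1 gives 2200 nM. Compound 2 gives only a limit in this assay, > 30000 nM. Among the compounds with values here, compound 1 thus holds the only real number among the two values, the other sitting at the limit of > 30000 nM in this assay, at which 1 of the 2 values shown sits.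

Compound 3 `O=C1C(=O)N(Cc2ccc(Oc3ccccn3)cc2)c2ccc(OC(F)(F)F)cc21` differs from compound 1 by hydrogen in place of methoxy on an aromatic carbon. Within the data shown here, no measured pair shows this change, so its size is open; a modest move toward weaker potency, a little beyond the usual scatter, is expected, and the step of a 2.3-fold higher number from compound 1 to compound 3 (0.36 log units; beyond the scatter) is what that expectation means. Compound 3 is therefore estimated at 5000 nM, within 1500 nM to 20000 nM.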

Compound 3, half-maximal effective concentration: 3200 nM
Estimate against measurement, compound 3: 1.6-fold (0.19 log units) above; the measured number falls inside the stated range.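

Replacing 6-methoxypyridin-2-yl with pyridin-2-yl gives a 1.5-fold higher number from compound 1 to compound 3 (0.16 log units; within the scatter), so the two compounds cannot be told apart in this assay. At this aromatic carbon, next to the ring nitrogen, a measurable effect therefore survives without the methoxy, at least when hydrogen takes its place. Nothing among the data shown explains this outcome.

Still open, on these data alone, is how a different group on this carbon, such as an amine, a fluorine or a longer ethoxy chain, would read out. Whether the ring nitrogen itself matters is also unanswered.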